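From Methyl to Isopropyl in a Well-Retained Series

The compounds below may be only part of what the source reports. "The series", "measured", "known", "first", "only" and "open" are said of these compounds alone.

Three related compounds have been measured in an ADME assay on microsomes from liver (Mus musculus) for metabolic stability, read by HPLC, with a stated time of 30 min; on this read-out lower numbers stand for a less stable compound and higher numbers for a more stable compound. Compound 1 `COc1ccc(NC(=O)C(=O)c2c[nH]c3cc(C)ccc23)cc1` gives 89.1%, compound 2 `Cc1ccc(NC(=O)C(=O)c2c[nH]c3cc(C)ccc23)cc1` gives 90.2% and compound 3 `O=C(Nc1ccc(-n2cccn2)cc1)C(=O)c1c[nH]c2cc(Cl)ccc12` gives 96.7%. Compound 2 therefore lies within the usual scatter of both other compounds, and the three cannot be ranked on these numbers.

The next compound, compound 4 `Cc1ccc(NC(=O)C(=O)c2c[nH]c3cc(C(C)C)ccc23)cc1`, alters compound 2 in one place: isopropyl in place of methyl on an aromatic carbon. This is isopropyl in place of methyl on an aromatic carbon of the core.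

Going by the values given here, only one measured step changes a single place, namely a number 1.1 percentage points higher from compound 1 to compound 2 (within the scatter). That step is small, but it is a different swap, methyl in place of methoxy, so it offers only indirect guidance. Among the compounds with values here, compound 3 differs from compound 2 in more than one place, and no measured compound shows what isopropyl does here.

With so little direct evidence, no clear shift beyond the scatter is expected in this assay, only a slightly lower number. The estimated change is a number 5.2 percentage points lower from compound 2 to compound 4 (within the scatter). For compound 4 the estimated value is 85%, with an expected range from 68% to 96%.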

Compound 4, percent of the compound remaining: 82.6%
For compound 4 the middle estimate is 2.4 percentage points above the measured one, and the stated range covers the measured number.
By their numbers in this assay, from the lowest: compounds 4, 1, 2 and 3 (each within the scatter of the next, the first and the last beyond it).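

At this position of the core, on a six-membered aromatic ring of carbon only, isopropyl in place of methyl gives a number 7.6 percentage points lower from compound 2 to compound 4 (within the scatter) in this assay. Going by these compounds alone, this is the first direct reading for this place, and it shows that going from a group of 1 heavy atom to one of 3 heavy atoms does not move the number beyond the spread expected when the same compound is simply measured again, so this single pair cannot be told apart from no real change. Nothing shown here tells what lies behind the number.

Still open, from the compounds shown here alone, is whether a different group at this same place, such as an amine, a carboxylic acid or a longer chain, would shift the number beyond the scatter when set against compound 2. Also open, going by these compounds, is whether isopropyl would act the same way with a different group at the far end of the molecule, for instance the methoxy that compound 1 carries where compound 2 has its other methyl.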